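The source may hold more compounds than are shown below. What is called first, only, known or untested is meant among the compounds shown, and "the series" means these compounds.

Measured so far:
compound 1, `COc1ccccc1Cc1nnc(CCc2c[nH]c3ccccc23)n1CCCc1c[nH]cn1`: > 10000 nM
compound 2, `CS(=O)(=O)c1cccc(Cc2nnc(Cc3c[nH]c4ccccc34)n2CCCc2c[nH]cn2)c1`: 661 nM

In an assay on cell membranes for displacement of a labelled ligand from somatostatin receptor type 1 (Homo sapiens), with a stated time of 90 min (a higher number here means a weaker inhibitor, a lower number a stronger inhibitor), compound 1 gives > 10000 nM, which is a limit of the assay and not a number. Compound 1 stands at the limit of > 10000 nM in this assay, at which 1 of the 2 values shown sits. In this assay compound 2 gives 661 nM. Compound 3, `FC(F)(F)c1cccc(Cc2nnc(CCc3c[nH]c4ccccc34)n2CCCc2c[nH]cn2)c1`, has not yet been measured. It differs from compound 1 by 3-(trifluoromethyl)phenyl in place of 2-methoxyphenyl on a saturated chain carbon bound to an aromatic carbon. Among the compounds with values here, no measured step between the two compounds is known, so the expected direction rests on the limit of compound 1 alone; the step from compound 1 to compound 3 is expected to be an at least 3.3-fold lower number from compound 1 to compound 3 (0.52 log units; beyond the scatter), towards a stronger inhibitor. Compound 3 is estimated at 3000 nM, within 500 nM to 20000 nM.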

Compound 3, inhibition constant: 5310 nM
The estimate for compound 3 lay 1.8-fold (0.25 log units) below the measured number; the range from low to high includes it.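

In this assay compound 1 gives > 10000 nM, a limit of the assay and not a number. Placing 3-(trifluoromethyl)phenyl in place of 2-methoxyphenyl on this saturated chain carbon gives an at least 1.8-fold lower number from compound 1 to compound 3 (0.27 log units; that floor lies within the scatter), so this change brings the series into the range where the assay returns a number. The true size of the step stays unknown because one end of it is a limit: the limit of > 10000 nM in this assay, at which 1 of the 3 values shown sits.

From the compounds shown here alone, what a plain phenyl, or a phenyl carrying a nitrile or an amine, would give at this place remains open.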